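This account rests on a few compounds, and the source may have more. Where it says the series, first, only, none or still open, it means among the compounds named here.

Series notes. Compound 1 `O=C1CC(c2ccccc2O)Oc2ccccc21` carries a free hydroxyl on its aromatic ring; in a functional assay on J774.A1 cells (Mus musculus) for inhibition, read by Griess assay, with stated times of 1 h and 24 h (a higher number here means a weaker inhibitor, a lower number a stronger inhibitor), compound 1 gives 71300 nM. Compound 2 `O=C1CC(c2ccccc2OCc2cccc(F)c2)Oc2ccccc21` bears a 3-fluorobenzyl on that oxygen, and in this assay compound 2 gives 13200 nM; the step is a 5.4-fold lower number from compound 1 to compound 2 (0.73 log units; beyond the scatter). Compound 3 `CC(C)=CCOc1ccccc1C1CC(=O)c2ccccc2O1` carries 3-methylbut-2-en-1-yl on the same oxygen; in this assay compound 3 gives 34300 nM, the second highest number of the three, with a 2.1-fold lower number from compound 1 to compound 3 (0.32 log units; beyond the scatter) and a 2.6-fold higher number from compound 2 to compound 3 (0.41 log units; beyond the scatter).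

Compound 4 `COCOc1ccccc1C1CC(=O)c2ccccc2O1` is not yet measured and differs from compound 3 as follows: methoxy in place of 2-methylprop-1-en-1-yl on a saturated chain carbon bound to an oxygen on an aromatic ring. Among the compounds with values here, the steps that bear on this are a 2.1-fold lower number from compound 1 to compound 3 (0.32 log units; beyond the scatter), where the leaving group entered in place of hydrogen, and a 2.6-fold higher number from compound 2 to compound 3 (0.41 log units; beyond the scatter), where it replaced 3-fluorophenyl. Both groups on the oxygen lowered the number relative to the hydrogen of compound 1, and the larger group of compound 2 did so most. Methoxy is smaller than either, so the expectation is a modest move back toward compound 1, a step of a 1.5-fold higher number from compound 3 to compound 4 (0.16 log units; within the scatter) in this assay. Compound 4 is therefore expected to give about 50000 nM in this assay, within 20000 nM to 120000 nM.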

Compound 4, half-maximal inhibitory concentration: 35200 nM
Beside the measured number, compound 4's estimate is 1.4-fold (0.15 log units) above it; the range from low to high includes it.
By their numbers in this assay, from the lowest: compound 2; then compounds 3 and 4 (each within the scatter of the next); then compound 1.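

In this assay, methoxy in place of 2-methylprop-1-en-1-yl on a saturated chain carbon bound to an oxygen on an aromatic ring gives a 1.0-fold higher number from compound 3 to compound 4 (0.01 log units; within the scatter) and so no readable difference, although the leaving group has a double bond and the entering group has a hydrogen-bond acceptor. Methoxymethyl in place of hydrogen on that oxygen gives a 2.0-fold lower number from compound 1 to compound 4 (0.31 log units; beyond the scatter) in this assay, so a lower number than that of compound 1 does not depend on the double bond of compound 3. Methoxy in place of 3-fluorophenyl gives a 2.7-fold higher number from compound 2 to compound 4 (0.43 log units; beyond the scatter) and, among these compounds, leaves only the 3-fluorobenzyl group of compound 2 apart from the other two groups on the oxygen.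

On these data alone, whether an unsubstituted benzyl, an amine or a carboxylic acid on this oxygen would stand with compound 2 or with compound 3 and compound 4 remains open. Nothing at hand bears on what lies behind these steps.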